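Dropping the isopropoxy group from compound 1

The source may hold more compounds than are shown below. What is called first, only, known or untested is meant among the compounds shown, and "the series" means these compounds.

Among the compounds with values here, compound 1 `COc1cc(-n2ncnc2-c2ccc(OC(C)C)cc2)cc(OC)c1OC` is the one compound of this set for which a number is known: in a functional assay on K562 cells (Homo sapiens) for antiproliferative activity, read by MTT assay, with a stated time of 72 h (on this read-out higher numbers stand for weaker inhibition and lower numbers for stronger inhibition), compound 1 gives 800 nM. Compound 2 `COc1cc(-c2ncnn2-c2ccccc2)cc(OC)c1OC` gives only a limit in this assay, > 10000 nM. Compound 3 `COc1cc(-c2ncnn2-c2ccc(Cl)cc2Cl)cc(OC)c1OC` likewise gives only a limit, > 10000 nM. Within the data shown here, the one measured step, a step that the two limits leave unreadable from compound 2 to compound 3, cannot be read because both of its values sit at the limit of > 10000 nM in this assay, at which 2 of the 3 values shown sit. Compound 4 `COc1cc(-n2ncnc2-c2ccccc2)cc(OC)c1OC` is not yet measured. It differs from compound 1 in one place: hydrogen in place of isopropoxy on an aromatic carbon. Among the measured compounds shown here, no measured step bears on this change, since compounds 2 and 3 share neither the isopropoxy group nor the way the shared core joins the two aromatic rings in compound 1. The expectation therefore rests on compound 1 alone. Compound 4 is expected to sit weaker than compound 1, with a step of a 3.8-fold higher number from compound 1 to compound 4 (0.57 log units; beyond the scatter), and an estimated value of 3000 nM, within a range from 800 nM to 10000 nM.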

Compound 4, half-maximal inhibitory concentration: > 10000 nM
Compound 4: only a limit was reported; the forecaster's own chance of this, stated with the estimate: 30%; middle value at least 3.3-fold (0.52 log units) from the limit.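

Hydrogen in place of isopropoxy, on the carbon para to a large group, gives the first readable step of this set (an at least 12-fold higher number from compound 1 to compound 4 (1.09 log units; beyond the scatter)). Within the data shown here, on the core of compound 1, the measurable antiproliferative activity therefore depends on the isopropoxy group at this position, a dependence that the earlier compounds could not show. In this assay compound 4 gives > 10000 nM as a limit and not a number, so the step marks only a lower bound on the loss: the limit of > 10000 nM in this assay, at which 3 of the 4 values shown sit.

The compounds shown leave open whether this position needs isopropoxy itself, or whether a methoxy group, a longer chain such as butoxy, or an amine would also keep the activity. They also leave open how far the activity of compound 4 actually lies beyond its limit.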